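The source may hold more compounds than are shown below. What is called first, only, known or untested is meant among the compounds shown, and "the series" means these compounds.

Measured so far:

compound 1, `CC(=O)NCCN(C)c1cccc(OCCCCN)c1`: 0.35
compound 2, `CC(=O)NCCN(C)c1cccc(OCCCCNC(=O)Oc2cccc(-c3ccccc3)c2)c1`: 0.39
compound 3, `CC(=O)NCCN(C)c1cccc(OCCCCCCNC(=O)Oc2cccc(-c3ccccc3)c2)c1`: 0.75

In a functional assay on cells for agonist activity at melatonin receptor type 1B (Homo sapiens), read by GTPgammaS binding, with a stated time of 30 min (a lower number here means a smaller maximal response, a higher number a larger maximal response), compound 3 gives 0.75, the highest of the three numbers. Compound 2 sits closest, with a value that is lower by more than the usual scatter, and compound 1 sits furthest, also lower by more than the scatter. For the measured compounds named here, no pair of these three differs in only one place, so no single step can be read from them; only the values themselves are known.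

Compound 4, `CC(=O)NCCN(C)c1cccc(OCCCCCCNC(=O)Oc2cccc(-c3cccc(O)c3)c2)c1`, is the next compound. Set beside compound 3, the change is hydroxy in place of hydrogen on an aromatic carbon. Going by the values given here, nothing among the measured compounds shows how a change of this kind plays out, so the expectation rests on compound 3 alone. The step expected is a number 0.050 lower from compound 3 to compound 4 (within the scatter), small and most likely within the scatter, in either direction. Compound 4 is therefore estimated at 0.7, within a range from 0.45 to 0.95.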

Compound 4, intrinsic activity: the largest response reached, as a fraction of the reference agonist's: 0.94
The estimate for compound 4 lay 0.24 below the measured number; the range from low to high includes it.
By their numbers in this assay, from the lowest: compounds 1 and 2 (each within the scatter of the next); then compound 3; then compound 4.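

In this assay, for the compounds shown here, changing phenyl to 3-hydroxyphenyl gives a number 0.19 higher from compound 3 to compound 4 (beyond the scatter), the first single change in this set whose effect can be read. So this position does more than accept a hydroxy group: adding one oxygen atom here is enough to raise the maximal response by a measurable amount. Nothing measured here explains the rise.

As far as these compounds go, whether hydroxy would have the same effect on another carbon of that ring remains open, as does whether a methoxy group, an amine or a carboxylic acid at this position would match it. It is also unknown whether the rise would carry over to the shorter chain of compound 2, or how the same change would behave on a longer chain.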